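This account rests on a few compounds, and the source may have more. Where it says the series, first, only, none or still open, it means among the compounds named here.

Measured so far in an ADME assay on cells (Hepatocyte, Rattus norvegicus) for metabolic stability; on this read-out lower numbers stand for a shorter-lived compound and higher numbers for a longer-lived compound:
- compound 1 `N#Cc1ccc(N2CCC(C(=O)N3N=CC[C@H]3c3cc(F)cc(F)c3)CC2)nn1`: 2.08 h
- compound 2 `Cc1nnc(N2CCC(C(=O)N3N=CC[C@H]3c3ccccc3)CC2)o1`: 2.88 h
- compound 3 `N#Cc1cnc(N2CCC(C(=O)N3N=CC[C@H]3c3cc(F)cc(F)c3)CC2)cn1`: 1.78 h

Compound 3, at 1.78 h, lies within the scatter of both compound 1 and compound 2, so the three values do not separate.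

The next compound is compound 4 `Cc1nnc(N2CCC(C(=O)N3N=CC[C@H]3c3cc(F)cc(F)c3)CC2)o1`. The change is 5-methyl-1,3,4-oxadiazol-2-yl in place of 5-cyanopyrazin-2-yl on an amine nitrogen in a ring.

Within the data shown here, only one measured step touches this place, a 1.2-fold lower number from compound 1 to compound 3 (0.07 log units; within the scatter). It exchanges one six-membered aromatic ring for another, so it says little about a five-membered ring entering. Compound 2 carries the same 5-methyl-1,3,4-oxadiazol-2-yl group and gives 2.88 h, but it has no fluorine, unlike compound 3, so it is only a loose guide.

Nothing measured points to a step beyond the scatter in this assay. The expected step is small, a 1.2-fold higher number from compound 3 to compound 4 (0.09 log units; within the scatter). The estimate for compound 4 is 2.2 h, with an expected range of 1.2 h to 3.8 h.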

Compound 4, half-life: 3.3 h
Compound 4: middle estimate off by 1.5-fold (0.18 log units), on the low side; measured number inside the range.
By their numbers in this assay, from the lowest: compounds 3, 1, 2 and 4 (each within the scatter of the next).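

In this assay, 5-methyl-1,3,4-oxadiazol-2-yl in place of 5-cyanopyrazin-2-yl on an amine nitrogen in a ring gives a step that stays within the scatter (a 1.9-fold higher number from compound 3 to compound 4 (0.27 log units; within the scatter)), and the comparison with the other six-membered aromatic ring reads the same way (a 1.6-fold higher number from compound 1 to compound 4 (0.20 log units; within the scatter)). A five-membered aromatic ring at this place therefore does not separate from either six-membered aromatic ring, and with 5-methyl-1,3,4-oxadiazol-2-yl held in place, 3,5-difluorophenyl in place of phenyl on a saturated ring carbon does not separate either (a 1.1-fold higher number from compound 2 to compound 4 (0.06 log units; within the scatter)). No measurement on hand accounts for any of these steps.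

All four compounds remain within the scatter of their neighbours, so no group at either place is yet shown to shift this read-out. Going by these compounds, whether an open-chain amine or a carboxylic acid on this ring nitrogen would separate from 5-methyl-1,3,4-oxadiazol-2-yl stays open.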